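Swapping the Triazole Group: Plasma Binding of Compound 4

This account rests on a few compounds, and the source may have more. Where it says the series, first, only, none or still open, it means among the compounds named here.

Compound 1 `Cc1ccc(-c2cc(C(=O)N[C@H](C)c3ccc(C(F)(F)F)nc3)cc(C(C)(C)O)c2)nc1`: 95.2%
Compound 2 `Cc1ccc(-c2cc(C(=O)N[C@@H](C)c3nnc[nH]3)cc(-c3ncccc3F)c2)nc1`: 98.8%
Compound 3 `Cc1ccc(-c2cc(C(=O)N[C@H](C)c3ccc(F)cn3)cc(-n3nccn3)c2)nc1`: 97.4%

In an ADME assay on a cell-free system (plasma, Rattus norvegicus) for protein binding, compound 2 gives 98.8%, the highest reading of the three and so the smallest free share. Compound 3 gives 97.4% and compound 1 gives 95.2%. Both leave more compound free than compound 2, and both gaps lie beyond the scatter. Near the top of this scale, a small gap in the bound share is a large gap in the free share.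

Compound 4 `Cc1ccc(-c2cc(C(=O)N[C@H](C)c3ccc(F)c[n+]3[O-])cc(-c3ncccc3F)c2)nc1` has not yet been measured. Its change from compound 2 is a group of 10 heavy atoms (7 carbon, 1 nitrogen, 1 oxygen, 1 fluorine; one six-membered aromatic ring with 1 hetero atom) in place of a group of 7 heavy atoms (4 carbon, 3 nitrogen; one five-membered aromatic ring with 3 hetero atoms), on an amide-type nitrogen. The 1-(4H-1,2,4-triazol-3-yl)ethyl group leaves, and a group with no common name enters on the same amide-type nitrogen.

For the measured compounds named here, no measured pair shows this change alone, so any expectation is rough. Compound 3 at 97.4% and compound 1 at 95.2% both carry a six-membered aromatic ring in the group on that nitrogen, though they also differ from compound 2 elsewhere. On that basis, a modest move towards more free compound is expected, with an estimated size of a 2.5-fold higher unbound fraction from compound 2 to compound 4 (0.40 log units; beyond the scatter). The estimate for compound 4 is 97%, with an expected range from 94% to 98.8%.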

Compound 4, plasma protein binding: 90.4%
Estimate against measurement, compound 4: 3.2-fold (0.51 log units) (unbound fraction) below; the whole stated range lies above it.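

For the compounds shown here, the step an 8.0-fold higher unbound fraction from compound 2 to compound 4 (0.90 log units; beyond the scatter) in this assay is the first measured change made at this place alone, on the amide-type nitrogen, with the rest of the molecule held the same. It shows that this group on its own can move the free share by an amount well beyond the scatter, so the binding of this series does not rest on the shared core alone. The swap changes several things at once, including ring size, the count of hetero atoms in the ring, and the loss of a hydrogen-bond donor, and no measurement here gives a reason for the size of the step.

Going by these compounds alone, what remains open is which of these differences carries the step, since the single comparison cannot divide it among them. A compound with the same core and the same six-membered ring on the amide-type nitrogen, but without the oxygen of the entering group, would isolate that atom, and a carboxylic acid or an amine on that ring would show how far this place can be pushed in either direction.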